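Swapping the Distal Heteroaryl on a Bombesin Receptor Agonist Series

The source may report more compounds than this note shows. Statements on the series, on what has been measured and on what is new or still open speak of the compounds shown alone.

Of the compounds shown here, three sharing one core have been measured. Compound 1 `CCC(C)(C)Cc1c[nH]c(CCc2ccc(-c3cccc(N)n3)cc2)n1` carries a 6-aminopyridin-2-yl group, and in a functional assay on HEK293 cells for agonist activity at Bombesin receptor subtype-3 (Mus musculus), read by luminescence and calcium flux, with a stated time of 10 min (a lower number here means that less compound is needed, a higher number that more compound is needed for the effect), compound 1 gives 119 nM. Compound 2 `CCC(C)(C)Cc1c[nH]c(CCc2ccc(-c3csnn3)cc2)n1` carries 1,2,3-thiadiazol-4-yl in that place; in this assay compound 2 gives 109 nM. Compound 3 `CCC(C)(C)Cc1c[nH]c(CCc2ccc(-c3cccc(C#N)n3)cc2)n1` carries 6-cyanopyridin-2-yl, and in this assay compound 3 gives 115 nM. Compound 1 stands at the highest of the three numbers, yet every difference among them lies within the scatter: a 1.1-fold lower number from compound 1 to compound 2 (0.04 log units; within the scatter), a 1.0-fold lower number from compound 1 to compound 3 (0.01 log units; within the scatter) and a 1.1-fold higher number from compound 2 to compound 3 (0.02 log units; within the scatter).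

Compound 4 `CCC(C)(C)Cc1c[nH]c(CCc2ccc(-n3ccnn3)cc2)n1` has not yet been measured. It differs from compound 1 in one place: 1H-1,2,3-triazol-1-yl in place of 6-aminopyridin-2-yl on an aromatic carbon. For the measured compounds named here, two measured steps bear on this change, from compound 1 to compound 2 and from compound 1 to compound 3. Both exchange the same group, and both stayed within the scatter. On that basis no step beyond the scatter is expected in this assay for the new exchange. Compound 4 is therefore estimated at 130 nM, with an expected range from 60 nM to 300 nM. This expectation corresponds to a step of a 1.1-fold higher number from compound 1 to compound 4 (0.04 log units; within the scatter).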

Compound 4, half-maximal effective concentration: 111 nM
Compound 4: the middle estimate sits 1.2-fold (0.07 log units) above what was measured; the measured number falls inside the stated range.
By their numbers in this assay, from the lowest: compounds 2, 4, 3 and 1 (each within the scatter of the next).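

In this assay the position para to the large group also accepts a 1H-1,2,3-triazol-1-yl group, a five-membered aromatic ring with 3 hetero atoms, 0 hydrogen-bond donors and 3 hydrogen-bond acceptors. Exchanging the other groups for it gives a 1.1-fold lower number from compound 1 to compound 4 (0.03 log units; within the scatter) and a 1.0-fold lower number from compound 3 to compound 4 (0.02 log units; within the scatter) and a 1.0-fold higher number from compound 2 to compound 4 (0.01 log units; within the scatter) and so adds a third ring type to the two already seen, with all four compounds within the scatter of one another and the smaller ring no different from either pyridine. Nothing available explains why the number holds so steady across these exchanges.

All four groups at this position are aromatic rings, so the compounds shown leave open whether a saturated ring such as piperidine or morpholine, a carboxylic acid, or a simple alkyl chain would take the number beyond the scatter. They also leave open whether these rings would stay level with one another if the 2,2-dimethylpropyl-type chain on the shared core were replaced by a shorter chain or a cyclohexyl group.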